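Replacing a Nitrophenyl with Biphenyl on an Inactive Scaffold

A few compounds are considered here, and "the series" means these few. Any claim that something is new, unique, unknown or untested is made for them only; others in the source may bear on it.

Three analogues built on a shared core have been tested in a functional assay on NIH3T3 cells (Mus musculus); on this read-out higher numbers stand for an effect only at larger amounts of compound and lower numbers for an effect already at smaller amounts. Compound 1 `N#Cc1ccc(Cn2cncc2CNc2ccc(C(=O)Nc3cccc([N+](=O)[O-])c3)c(-c3ccccc3)c2)cc1` reaches only the limit of > 10 uM in this assay, so no number is known for it. Compound 2 `CSCC[C@H](NC(=O)c1ccc(NCc2cncn2Cc2cccc(C)c2)cc1-c1ccccc1)C(=O)O` likewise stops at the limit of > 10 uM. Compound 3 `COC(=O)[C@H](CCSC)NC(=O)c1ccc(NCc2cncn2Cc2cccc([N+](=O)[O-])c2)cc1-c1ccccc1` also gives only the limit of > 10 uM in this assay. Compound 3 therefore stands exactly where every value so far stands, at the limit of > 10 uM in this assay, at which 3 of the 3 values shown sit, and nothing separates it from compound 1 or compound 2 on the numbers shown.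

Compound 4 `COC(=O)[C@H](CCSC)NC(=O)c1ccc(NCc2cncn2Cc2ccc(-c3ccccc3)cc2)cc1-c1ccccc1` differs from compound 3 in one place: 4-phenylphenyl in place of 3-nitrophenyl on a saturated chain carbon bound to an aromatic nitrogen. Going by the values given here, no measured pair shows how such a swap acts in this assay, so there is no comparison to build on. The step that the limit leaves unreadable from compound 3 to compound 4 that the estimate for compound 4 implies is small, with no direction favoured beyond the usual scatter. Compound 4 is thus estimated at 15 uM in this assay, within 3 uM to 60 uM, and the reading may well again be only a limit.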

Compound 4, concentration for half-maximal effect: > 10 uM
Compound 4 ended at the assay's limit; the forecaster's own chance of this, stated with the estimate: 70%; the middle value is on the limit's open side.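

Going by these compounds alone, compound 3 and compound 4 both end at a limit of the assay, so no step between them can be read: the limit of > 10 uM in this assay, at which 4 of the 4 values shown sit. The compounds shown leave open how 4-phenylphenyl and 3-nitrophenyl truly compare in this assay and what change on the shared core would bring a measurable value there.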